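This account rests on a few compounds, and the source may have more. Where it says the series, first, only, none or still open, it means among the compounds named here.

Compounds measured in an assay on isolated protein for inhibition of thiosulfate sulfurtransferase (Homo sapiens), with a stated time of 60 min, in the absence of a further agent; a lower number here means a stronger inhibitor, a higher number a weaker inhibitor:
Compound 1 `O=C(Nc1ccccc1)c1cc(Br)ccc1O` gives > 100000 nM.
Compound 2 `O=C(Nc1ccc(Sc2nc3ccccc3s2)c(Cl)c1)c1cccc(Br)c1O` gives > 100000 nM.

For compound 1 the value is a limit of this assay, not a number. For compound 2 the value is likewise a limit. Going by the values given here, compound 2 thus stands at the limit of > 100000 nM in this assay, at which 2 of the 2 values shown sit, and no step between measured compounds exists to lean on.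

Compound 3 `COc1ccccc1C(=O)Nc1ccc(Sc2nc3ccccc3s2)c(Cl)c1` differs from compound 2 by 2-methoxyphenyl in place of 3-bromo-2-hydroxyphenyl on a carbonyl carbon. With nothing measured to guide it, the expected step of a number no higher from compound 2 to compound 3 (the limit leaves the size open) is none beyond the scatter. Compound 3 is therefore expected to show 100000 nM, ranging from 30000 nM to 300000 nM, most likely again only a limit.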

Compound 3, half-maximal inhibitory concentration: > 100000 nM
Compound 3: no number, only a limit; the forecaster's own chance of this, stated with the estimate: 85%; the middle value lies on the limit itself.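

Compound 3, like compound 2, gives only a limit and not a number, so the step between them cannot be read. The compounds shown leave open which structure, if any, would give a measurable value: the limit of > 100000 nM in this assay, at which 3 of the 3 values shown sit.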